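A few compounds are considered here, and "the series" means these few. Any claim that something is new, unique, unknown or untested is made for them only; others in the source may bear on it.

Measured in a functional assay on K562 cells (Homo sapiens) for inhibition, read by MTT assay, with a stated time of 48 h; on this read-out higher numbers stand for weaker inhibition and lower numbers for stronger inhibition:
compound 1, `CC(=O)Nc1ccc(-c2cn([C@@H]3CN[C@H](C(=O)Nc4ccc(Cl)c(C(F)(F)F)c4)C3)nn2)cn1`: 8980 nM
compound 2, `O=C(Nc1ccc(-c2cn([C@@H]3CN[C@H](C(=O)Nc4ccc(Cl)c(C(F)(F)F)c4)C3)nn2)cn1)C1CC1`: 8770 nM
compound 3, `CC(=O)Nc1n[nH]c2cc(-c3cn([C@@H]4CN[C@H](C(=O)Nc5ccc(Br)cc5)C4)nn3)ccc12`: 3830 nM

Compound 1 and compound 2 share a core and differ only by cyclopropyl in place of methyl on a carbonyl carbon; this change gave a 1.0-fold lower number from compound 1 to compound 2 (0.01 log units; within the scatter). Compound 3 stands on a different core, and the difference between the two cores is not broken down here; its number in this assay lies beyond the scatter from those of compound 1 and compound 2.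

Compound 4, `O=C(Nc1n[nH]c2cc(-c3cn([C@@H]4CN[C@H](C(=O)Nc5ccc(Br)cc5)C4)nn3)ccc12)C1CC1`, has not yet been measured. It carries the same change on the core of compound 3, (cyclopropyl in place of methyl on a carbonyl carbon), at the same kind of place as before. Because the earlier step was a 1.0-fold lower number from compound 1 to compound 2 (0.01 log units; within the scatter), the step from compound 3 to compound 4 is expected to be small as well, a 1.0-fold lower number from compound 3 to compound 4 (0.01 log units; within the scatter). Compound 4 is therefore estimated at 3700 nM, with a likely range from 1800 nM to 7500 nM.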

Compound 4, half-maximal inhibitory concentration: 8080 nM
Compound 4: middle estimate off by 2.2-fold (0.34 log units), on the low side; the whole stated range lies below it.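

In this assay cyclopropyl in place of methyl on a carbonyl carbon gave a 2.1-fold higher number from compound 3 to compound 4 (0.32 log units; beyond the scatter), while on the core of compound 1 the same change gave a 1.0-fold lower number from compound 1 to compound 2 (0.01 log units; within the scatter). Set side by side, the two steps cannot be told apart: the same change on two cores in this assay, a 1.0-fold lower number (0.01 log units; within the scatter) from compound 1 to compound 2 and a 2.1-fold higher number (0.32 log units; beyond the scatter) from compound 3 to compound 4, 2.2-fold (0.33 log units) apart, within the scatter of two such steps. For the compounds shown here, the pairs therefore give no firm sign that the core alters the outcome of this change, but two pairs cannot show that it carries over unchanged, and only the step on the core of compound 3 lies beyond the scatter.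

Going by these compounds, it remains open how a longer chain such as propyl, or an amine, on the same carbonyl carbon would behave on either core. On these data alone, how the change would behave on a third core also remains open.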